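The compounds below may be only part of what the source reports. "The series", "measured", "known", "first", "only" and "open" are said of these compounds alone.

Among the compounds with values here, compound 2 `COc1ccc2nc(C)cc(OCC(=O)Nc3ccncn3)c2c1` carries the only full number in a physicochemical assay for solubility, in phosphate buffer, measured as kinetic solubility, with a stated time of 1 h, at pH 7.4 (on this read-out lower numbers stand for lower solubility and higher numbers for higher solubility), where compound 2 gives 27500 nM. Compound 1 `COc1ccc2nc(C)cc(OCC(=O)Nc3ccc(Br)c(C)c3)c2c1` is reported in this assay only as a limit, < 1000 nM, (the limit of < 1000 nM in this assay, at which 1 of the 2 values shown sits). Within the data shown here, the single measured step, an at least 27-fold higher number from compound 1 to compound 2 (1.43 log units; beyond the scatter), swaps the whole amide substituent and so does not bear directly on the change to compound 3 `COc1ccc2nc(C)cc(OCC(=O)Nc3cc(C)nc(C)n3)c2c1`, which is 2,6-dimethylpyrimidin-4-yl in place of pyrimidin-4-yl on an amide-type nitrogen. Among the measured compounds shown here, with no measured step of this kind, a modest drop is expected for compound 3, a 1.8-fold lower number from compound 2 to compound 3 (0.26 log units; within the scatter), giving an estimated 15000 nM within 5000 nM to 40000 nM.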

Compound 3, solubility: 5000 nM
For compound 3 the middle estimate is 3.0-fold (0.48 log units) above the measured one, and the stated range covers the measured number.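

In this assay, the exchange of pyrimidin-4-yl for 2,6-dimethylpyrimidin-4-yl on the amide-type nitrogen gives a 5.5-fold lower number from compound 2 to compound 3 (0.74 log units; beyond the scatter), so this position responds to a small change to the ring and not only to replacement of the whole substituent. The dimethylated ring still keeps a clear margin over 4-bromo-3-methylphenyl, with an at least 5.0-fold higher number from compound 1 to compound 3 (0.69 log units; beyond the scatter). The value of compound 1 is a limit and not a number: the limit of < 1000 nM in this assay, at which 1 of the 3 values shown sits. On these data alone, whether one methyl group alone would give the same drop stays open, as does the effect of an amine or a methoxy group on that ring.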